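Cyano for methoxy on the sulfonyl aryl series

A few compounds are considered here, and "the series" means these few. Any claim that something is new, unique, unknown or untested is made for them only; others in the source may bear on it.

Measured in a functional assay on MDA-MB-231 cells (Homo sapiens) for antiproliferative activity, read by MTT assay, with a stated time of 24 h; a higher number here means a weaker inhibitor, a lower number a stronger inhibitor:
- compound 1 `O=C1CC[C@@H](C(=O)N2CCN(c3nccc(Oc4cc(Cl)cc(Cl)c4)n3)CC2)N1`: > 50000 nM (a limit)
- compound 2 `CC(C)(C)c1ccc(S(=O)(=O)N2CCN(c3nccc(Oc4cc(Cl)cc(Cl)c4)n3)CC2)cc1`: > 50000 nM (a limit)
- compound 3 `COc1ccc(S(=O)(=O)N2CCN(c3nccc(Oc4cc(Cl)cc(Cl)c4)n3)CC2)cc1`: 46800 nM

Within the data shown here, compound 3 holds the only actual number in this small set, at 46800 nM. The rest of the set is defined by the limit of > 50000 nM in this assay, at which 2 of the 3 values shown sit.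

The next structure, compound 4 `N#Cc1ccc(S(=O)(=O)N2CCN(c3nccc(Oc4cc(Cl)cc(Cl)c4)n3)CC2)cc1`, has cyano in place of methoxy on an aromatic carbon, para to a large group: cyano in place of methoxy on an aromatic carbon.

Among the measured compounds shown here, one measured step bears on this change, since it alters the same substituent: an at least 1.0-fold lower number from compound 2 to compound 3 (0.02 log units; that floor lies within the scatter). It gives no measured size beyond the scatter, and the evidence for this substituent is thin. No step beyond the scatter is therefore expected in this assay, and no direction can be favoured. A result reported only as a limit would be unsurprising.

The expected change is a 1.1-fold higher number from compound 3 to compound 4 (0.03 log units; within the scatter). For compound 4 the estimated value is 50000 nM, with an expected range of 20000 nM to 100000 nM.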

Compound 4, half-maximal inhibitory concentration: 24800 nM
Estimate against measurement, compound 4: 2.0-fold (0.30 log units) above; the measured number falls inside the stated range.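

Cyano in place of methoxy on an aromatic carbon, para to a large group, gives a 1.9-fold lower number from compound 3 to compound 4 (0.28 log units; within the scatter) in this assay, so this position now carries a second actual number, but the change does not separate the two substituents. Against tert-butyl at the same place, the reading is an at least 2.0-fold lower number from compound 2 to compound 4 (0.30 log units; that floor lies within the scatter); this step rests on a limit, sets only a floor and shows no step beyond the scatter. Limits still mark the set: the limit of > 50000 nM in this assay, at which 2 of the 4 values shown sit.

On these data alone, whether any substituent at this aromatic carbon can move the number beyond the scatter stays open, including an amine, a carboxylic acid or a longer chain. Also open, as far as these compounds go, is whether changes to the shared core would do more than changes at this position.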